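The source may hold more compounds than are shown below. What is called first, only, known or untested is meant among the compounds shown, and "the series" means these compounds.

Measured compounds in a functional assay on A549 cells (Homo sapiens) for antiproliferative activity, read by MTT assay, with a stated time of 72 h; on this read-out higher numbers stand for weaker inhibition and lower numbers for stronger inhibition:

- compound 1, `COc1cc(OC)c2c(=O)n(-c3cccc(C(=O)N4CCCCC4)c3)ccc2c1`, gives 18600 nM
- compound 2, `COc1cc(O)c2c(=O)n(-c3cccc(C(=O)N4CCCCC4)c3)ccc2c1`, gives 14200 nM
- compound 3, `COc1cc2c(c(OC)c1)C(=O)N(c1cccc(C(=O)N3CCCCC3)c1)CC2`, gives 23400 nM

Compound 1 and compound 2 share a core and differ in one place: hydrogen in place of methyl on an oxygen on an aromatic ring. This change gave a 1.3-fold lower number from compound 1 to compound 2 (0.12 log units; within the scatter), so the two values sit within the usual scatter of each other and no direction can be read from them. The core of compound 3 is not that of compound 1; the difference between the two cores is not broken down here. The value of compound 3 and that of compound 1 also lie within the scatter of each other, as do those of compound 3 and compound 2, so the three measured compounds are not separated by this assay.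

Compound 4, `COc1cc(O)c2c(c1)CCN(c1cccc(C(=O)N3CCCCC3)c1)C2=O`, is not yet measured. It stands to compound 3 as compound 2 stands to compound 1: hydrogen in place of methyl on an oxygen on an aromatic ring. The place of the change is the same in both pairs, so this is the same change on a second core. Within the data shown here, with only one earlier instance to go on, the expectation for compound 4 rests on compound 1 and compound 2, where the change gave a 1.3-fold lower number from compound 1 to compound 2 (0.12 log units; within the scatter), and the step is expected to be of similar size, a 1.3-fold lower number from compound 3 to compound 4 (0.11 log units; within the scatter). Among the measured compounds shown here, on that basis compound 4 is estimated at 18000 nM in this assay, with a plausible range from 9000 nM to 36000 nM; the range is wide because the single precedent a 1.3-fold lower number from compound 1 to compound 2 (0.12 log units; within the scatter) is itself within the scatter and the core of compound 3 is a different one.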

Compound 4, half-maximal inhibitory concentration: 13200 nM
Estimate against measurement, compound 4: 1.4-fold (0.13 log units) above; the range from low to high includes it.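

Replacing methoxy with hydroxy on the second core in this assay gave a 1.8-fold lower number from compound 3 to compound 4 (0.25 log units; within the scatter), so this step, like the one on the first core, has no direction that can be read on its own. Set side by side, the two steps do not differ in size by more than repeated measurement allows: the same change on two cores in this assay, a 1.3-fold lower number (0.12 log units; within the scatter) from compound 1 to compound 2 and a 1.8-fold lower number (0.25 log units; within the scatter) from compound 3 to compound 4, 1.4-fold (0.13 log units) apart, within the scatter of two such steps. This shows that, across these two cores, nothing in the data separates the change on one core from the same change on the other, but it does not show that the change has a real effect on either core, nor that the agreement would hold on a third core or in another read-out.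

The compounds shown compare only methoxy and hydroxy at this oxygen, with all four values in one narrow band, so it remains open whether an ethoxy group, a longer chain ending in an amine, or a carboxylic acid at that place would give a step beyond the scatter. On these data alone, it also remains open whether an open-chain amine in place of the present amine part of the amide would move the values on either core, and whether the two cores would then still track each other.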